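This account rests on a few compounds, and the source may have more. Where it says the series, first, only, none or still open, it means among the compounds named here.

Compound 1 `COc1cc(/C=C/c2ccccc2)c(-c2ccccc2)c(OC)c1OC`: 79000 nM
Compound 2 `C=C(c1ccc(OC)cc1)c1cc(OC)c(OC)c(OC)c1-c1ccccc1`: 22000 nM

In a functional assay on A549 cells (Homo sapiens) for cytotoxicity, read by MTT assay, with a stated time of 48 h (on this read-out lower numbers stand for stronger inhibition and higher numbers for weaker inhibition), compound 2 has the lower of the two numbers at 22000 nM, and compound 1 gives 79000 nM. The gap between these two numbers lies beyond the scatter. Compound 3 `C=C(c1ccccc1)c1cc(OC)c(OC)c(OC)c1-c1ccccc1` has hydrogen in place of methoxy on an aromatic carbon, para to a large group (hydrogen in place of methoxy on an aromatic carbon). Within the data shown here, no measured pair isolates this change, so the expectation in this assay is tentative: a modest move toward a higher number, possibly not beyond the scatter. The estimated step is a 1.6-fold higher number from compound 2 to compound 3 (0.20 log units; within the scatter). Compound 3 is expected at 35000 nM, within an estimated range of 14000 nM to 85000 nM.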

Compound 3, half-maximal inhibitory concentration: 17000 nM
Compound 3: the middle estimate sits 2.1-fold (0.31 log units) above what was measured, and the stated range covers the measured number.
By their numbers in this assay, from the lowest: compounds 3 and 2 (each within the scatter of the next); then compound 1.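

In this assay, hydrogen in place of methoxy gives a 1.3-fold lower number from compound 2 to compound 3 (0.11 log units; within the scatter), so the change from 4-methoxyphenyl to phenyl, the first measured at this position, does not move the number beyond the scatter. With 1-phenylethenyl in place of 2-phenylethenyl, the data show a 4.6-fold lower number from compound 1 to compound 3 (0.67 log units; beyond the scatter), a modest step beyond the scatter and the larger of the two. No available measurement accounts for either step.

On these data alone, whether an amine or a hydroxy group on this aromatic carbon, para to a large group, would shift the number beyond the scatter remains open. Also open, as far as these compounds go, is whether the step from 2-phenylethenyl to 1-phenylethenyl holds in other cell lines.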